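The compounds below may be only part of what the source reports. "The series", "measured", "known", "first", "only" and "open" are said of these compounds alone.

Three compounds have been measured in a functional assay on C6 cells (Rattus norvegicus) for cytotoxicity, read by MTT assay, with a stated time of 24 h; a higher number here means a weaker inhibitor, a lower number a stronger inhibitor:
Compound 1 `Cc1ccc(-c2cs/c(=N/NC(=O)CSc3nncn3C)n2-c2ccccc2)cc1` gives 56 ug/mL.
Compound 2 `Cc1ccc(-c2cs/c(=N/NC(=O)CSc3nnnn3C)n2-c2ccccc2)cc1` gives 36.3 ug/mL.
Compound 3 `Cn1cnnc1SCC(=O)N/N=c1/scc(-c2ccc(C#N)cc2)n1-c1ccccc1` gives only a limit of the assay, > 200 ug/mL.

Compounds 1 and 2 share a core and differ in one place: 1-methyl-1H-tetrazol-5-yl in place of 4-methyl-4H-1,2,4-triazol-3-yl on a sulfur. This change gives a 1.5-fold lower number from compound 1 to compound 2 (0.19 log units; within the scatter). Compounds 1 and 3 differ at another place: cyano in place of methyl on an aromatic carbon. Here the step is an at least 3.5-fold higher number from compound 1 to compound 3 (0.55 log units; beyond the scatter), and the value of compound 3 sits at the limit of > 200 ug/mL in this assay, at which 1 of the 3 values shown sits, so the full size of that step is not known.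

Compound 4 `Cn1nnnc1SCC(=O)N/N=c1/scc(-c2ccc(C#N)cc2)n1-c1ccccc1` has not yet been measured. It differs from compound 3 by the same change that separates compound 2 from compound 1: 1-methyl-1H-tetrazol-5-yl in place of 4-methyl-4H-1,2,4-triazol-3-yl on a sulfur. Since the earlier step of a 1.5-fold lower number from compound 1 to compound 2 (0.19 log units; within the scatter) was within the scatter, and since compound 3 already stands at a limit, the step is expected to be small, a step that the limit leaves unreadable from compound 3 to compound 4. Compound 4 is therefore expected to give about 250 ug/mL in this assay, most likely between 120 ug/mL and 600 ug/mL, and quite possibly to be reported once more only as a limit.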

Compound 4, half-maximal inhibitory concentration: 23.3 ug/mL
The estimate for compound 4 lay 11-fold (1.03 log units) above the measured number, and the stated range ends above it.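

In this assay, the swap on the sulfur from 4-methyl-4H-1,2,4-triazol-3-yl to 1-methyl-1H-tetrazol-5-yl gives an at least 8.5-fold lower number from compound 3 to compound 4 (0.93 log units; beyond the scatter), so its size did not carry over from one core to the other: the same change on two cores in this assay, a 1.5-fold lower number (0.19 log units; within the scatter) from compound 1 to compound 2 and an at least 8.5-fold lower number (0.93 log units; beyond the scatter) from compound 3 to compound 4, at least 5.5-fold (0.74 log units) apart, beyond the scatter of two such steps. With the 1-methyl-1H-tetrazol-5-yl group in place, cyano for methyl gives a 1.6-fold lower number from compound 2 to compound 4 (0.19 log units; within the scatter), which also differs from the same change made with the other ring: the same change on two cores in this assay, an at least 3.5-fold higher number (0.55 log units; beyond the scatter) from compound 1 to compound 3 and a 1.6-fold lower number (0.19 log units; within the scatter) from compound 2 to compound 4, at least 5.5-fold (0.74 log units) apart, beyond the scatter of two such steps. Compound 3 gives only a limit of the assay, > 200 ug/mL, so the full size of these gaps stays unknown, and this single pair of cores cannot explain the mismatch or predict the swap on a third core.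

From the compounds shown here alone, the aromatic carbon here carries only methyl or cyano, so it remains open how a chlorine atom or a methoxy group there would behave with either ring on the sulfur. Going by these compounds, it also remains open whether the mismatch would persist with an ethyl group in place of the methyl on each ring.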